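One Swap of Chloro for Amino, Seen Twice

This account rests on a few compounds, and the source may have more. Where it says the series, first, only, none or still open, it means among the compounds named here.

Of the compounds shown here, three have been tested so far in a functional assay on BT-549 cells (Homo sapiens) for cytotoxicity, read by sulforhodamine B assay, with a stated time of 48 h; a lower number here means a stronger inhibitor of growth, a higher number a weaker inhibitor of growth. Compound 1 `ClCc1ccccc1Cn1cnc2c(Cl)nc(Cl)nc21` gives 1470 nM. Compound 2 `ClCc1cccc(Cn2cnc3c(Cl)nc(Cl)nc32)c1` has the same atoms joined differently; the difference between the two cores is not broken down here, and in this assay compound 2 gives 3230 nM. Compound 3 `Nc1nc(Cl)c2ncn(Cc3ccccc3CCl)c2n1` differs from compound 1 by one change, (amino in place of chloro on an aromatic carbon), and in this assay compound 3 gives 22900 nM. That change produced a 16-fold higher number from compound 1 to compound 3 (1.19 log units; beyond the scatter), so the growth of the cells was fully held back only at a much greater concentration once the chloro group had been replaced.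

Compound 4 `Nc1nc(Cl)c2ncn(Cc3cccc(CCl)c3)c2n1` has not yet been measured. Among the compounds with values here, it differs from compound 2 by amino in place of chloro on an aromatic carbon, which is the same change as the one from compound 1 to compound 3, at the same place. Because a 16-fold higher number from compound 1 to compound 3 (1.19 log units; beyond the scatter) was large and beyond the scatter, a step of similar size is expected from compound 2 to compound 4, namely a 15-fold higher number from compound 2 to compound 4 (1.19 log units; beyond the scatter). This expectation rests on one earlier instance of the change and on the number for compound 2, 3230 nM; with a single example, the size of the step could turn out different. Compound 4 is therefore estimated to give 50000 nM in this assay, with a likely span from 15000 nM to 150000 nM.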

Compound 4, concentration for total growth inhibition: 17400 nM
Compound 4: the middle estimate sits 2.9-fold (0.46 log units) above what was measured, and the stated range covers the measured number.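

In this assay the swap of chloro for amino again weakens growth inhibition, with a 5.4-fold higher number from compound 2 to compound 4 (0.73 log units; beyond the scatter), so the direction of the change carries over from the core of compound 1 to the core of compound 2. The size of the step does not carry over, and the gap between the two steps is larger than repeat measurements would explain: the same change on two cores in this assay, a 16-fold higher number (1.19 log units; beyond the scatter) from compound 1 to compound 3 and a 5.4-fold higher number (0.73 log units; beyond the scatter) from compound 2 to compound 4, 2.9-fold (0.46 log units) apart, beyond the scatter of two such steps These two pairs show that the core can alter how much this swap costs, but they do not show why the cost differs, and two examples cannot establish a rule for any further core in the series.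

The compounds shown carry only chloro or amino at this position, so it remains open how a methoxy group or a methylamino group would behave there, and whether either would cost less on one core than on the other. From the compounds shown here alone, it also remains open whether the difference between the two steps would persist with a bromomethyl group in place of the chloromethyl group that all four compounds share.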